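Removing one trifluoromethyl group from compound 1

A few compounds are considered here, and "the series" means these few. Any claim that something is new, unique, unknown or untested is made for them only; others in the source may bear on it.

Going by the values given here, in a functional assay on DU-145 cells (Homo sapiens) for inhibition, read by sulforhodamine B assay, with a stated time of 48 h (a lower number here means that less compound is tolerated, a higher number that more compound is tolerated), compound 1 `COc1cc(-c2nn(-c3cccc(NC(=O)Nc4cc(C(F)(F)F)cc(C(F)(F)F)c4)c3)cc2-c2ccncc2)ccc1Cl` gives 21100 nM, the only exact number among the three compounds measured. Compound 2 `COc1cc(-c2nn(-c3cccc(NC(=O)c4cccc(C(F)(F)F)c4)c3)cc2-c2ccncc2)ccc1Cl`, which carries a single trifluoromethyl, has a result that is a limit, > 50000 nM. Compound 3 `O=C(Nc1cccc(-n2cc(-c3ccncc3)c(-c3ccc(Cl)c(O)c3)n2)c1)Nc1ccc(Cl)c(Cl)c1` also has a result that is a limit, > 32500 nM.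

Compound 4 `COc1cc(-c2nn(-c3cccc(NC(=O)Nc4cccc(C(F)(F)F)c4)c3)cc2-c2ccncc2)ccc1Cl` is compound 1 with hydrogen in place of trifluoromethyl on an aromatic carbon. Among the compounds with values here, no measured pair shows this change, so the expectation is loose. In this assay, a small upward step, close to the usual scatter, is expected, starting from compound 1 at 21100 nM. The estimated step is a 1.4-fold higher number from compound 1 to compound 4 (0.15 log units; within the scatter). Compound 4 is expected at 30000 nM, with an estimated range of 13000 nM to 50000 nM.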

Compound 4, concentration lethal to 50% of the cells: > 50000 nM
Compound 4 was reported as a limit; the forecaster's own chance of this, stated with the estimate: 40%; middle value at least 1.6-fold (0.22 log units) from the limit.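

In this assay, replacing one trifluoromethyl with hydrogen gives an at least 2.3-fold higher number from compound 1 to compound 4 (0.37 log units; beyond the scatter), the first sign that cells tolerate more compound without this group at this position. The result for compound 4 is a limit, so only the lowest possible size of this step is known: the limit of > 50000 nM in this assay, at which 2 of the 4 values shown sit. The step from compound 2 to compound 4 cannot be read, as both results are limits.

Going by these compounds, it remains open what an amine or a carboxylic acid would give in place of this trifluoromethyl. On these data alone, the exact value for compound 4 also remains unknown.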